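A few compounds are considered here, and "the series" means these few. Any claim that something is new, unique, unknown or untested is made for them only; others in the source may bear on it.

In a functional assay on HepG2 cells (Homo sapiens) for cytotoxicity, read by MTT assay, with a stated time of 48 h (a lower number here means a stronger inhibitor, a higher number a weaker inhibitor), three compounds that share one core have been measured. Compound 1 `O=C(CSc1nnc(-c2ccncc2)o1)N/N=C/c1ccccc1` gives 17300 nM. Compound 2 `Cc1ccc(/C=N/NC(=O)CSc2nnc(-c3ccncc3)o2)cc1` gives 10000 nM, and compound 3 `O=C(CSc1nnc(-c2ccncc2)o1)N/N=C/c1ccccc1O` gives 3510 nM. Compound 3 therefore stands lowest of the three numbers; its nearest neighbour is compound 2, and the gap to compound 1 is the widest. The step that turns compound 3 into compound 4 `O=C(CSc1nnc(-c2ccncc2)o1)N/N=C/c1cc(Br)cc(Br)c1O` is 3,5-dibromo-2-hydroxyphenyl in place of 2-hydroxyphenyl on a carbon with a double bond to nitrogen. Within the data shown here, no measured step adds bromine, so nothing shows directly what these two bromine atoms do. Among the measured compounds shown here, the steps that bear on the question are those that alter the same ring: a 4.9-fold lower number from compound 1 to compound 3 (0.69 log units; beyond the scatter), a 2.8-fold lower number from compound 2 to compound 3 (0.45 log units; beyond the scatter) and a 1.7-fold lower number from compound 1 to compound 2 (0.24 log units; within the scatter). Two of these three changes on this ring moved the number beyond the scatter, and both moved it downward, which suggests that a further change at this ring can again shift the result by a modest amount. With the hydroxy group kept and two bromine atoms added, a modest further lowering in this assay is expected for compound 4, though a result within the scatter of compound 3 would not be surprising. The expected step is a 2.3-fold lower number from compound 3 to compound 4 (0.37 log units; beyond the scatter). Compound 4 is estimated at 1500 nM, with a range from 400 nM to 6000 nM.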

Compound 4, half-maximal inhibitory concentration: 6540 nM
Beside the measured number, compound 4's estimate is 4.4-fold (0.64 log units) below it; the measured number lies above the stated range.
By their numbers in this assay, from the lowest: compounds 3, 4, 2 and 1 (each within the scatter of the next, the first and the last beyond it).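

In this assay the two bromine atoms added to the hydroxy-bearing ring give no change that this assay can separate from the scatter (a 1.9-fold higher number from compound 3 to compound 4 (0.27 log units; within the scatter)), so this position tolerates the 3,5-dibromo-2-hydroxyphenyl group, with its 9 heavy atoms against 7, without a clear gain or loss. The picture of the hydroxy group also becomes less simple: both hydroxy compounds stand apart from the plain phenyl compound, as the new comparison shows (a 2.6-fold lower number from compound 1 to compound 4 (0.42 log units; beyond the scatter)), and the methyl compound does not, yet compound 4 goes against any clean hydroxy-over-methyl pattern, since its step from the methyl compound stays within the scatter (a 1.5-fold lower number from compound 2 to compound 4 (0.18 log units; within the scatter)), unlike that of compound 3. No measurement available here offers a reason for these numbers.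

The compounds shown leave open what a single bromine atom would do on its own, and whether the hydroxy group still matters once bromine is present. They also leave open how an amine or a carboxylic acid in place of that hydroxy group would read in this assay on this ring.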